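Propoxy Added to the Biaryl Amine Acid Scaffold

The source may hold more compounds than are shown below. What is called first, only, known or untested is meant among the compounds shown, and "the series" means these compounds.

Measured compounds:
compound 1 `Cc1ccccc1-c1cccc(CNc2ccc(OCC(=O)O)c(F)c2)c1`: 2.41
compound 2 `CC(C)c1ccccc1-c1cccc(CNc2ccc(OCC(=O)O)c(F)c2)c1`: 3.45

For the measured compounds named here, in a physicochemical assay for lipophilicity, read by HPLC, in phosphate buffer, measured as octanol-water partition, at pH 7.4, tested at 100 uM (on this read-out higher numbers stand for higher lipophilicity and lower numbers for lower lipophilicity), compound 1 gives the lower of the two numbers, with compound 2 the only comparison. Going by the values given here, the one measured step, a number 1.04 log units higher from compound 1 to compound 2 (beyond the scatter), shows that a larger alkyl group at an aromatic carbon raises the read-out substantially. Compound 3 `CCCOc1ccc(-c2cccc(CNc3ccc(OCC(=O)O)c(F)c3)c2)c(C)c1` differs from compound 1 by propoxy in place of hydrogen on an aromatic carbon, which adds four heavy atoms to the aromatic ring. A step in the same direction, of comparable or somewhat greater size, is expected, namely a number 1.19 log units higher from compound 1 to compound 3 (beyond the scatter). Compound 3 is therefore estimated at 3.6, in the range 3 to 4.2.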

Compound 3, distribution coefficient: 3.37
For compound 3 the middle estimate is 0.23 log units above the measured one, within the range that was stated.
By their numbers in this assay, from the lowest: compound 1; then compounds 3 and 2 (each within the scatter of the next).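

At the carbon para to a large group and meta to a methyl group, propoxy in place of hydrogen gives a number 0.96 log units higher from compound 1 to compound 3 (beyond the scatter) in this assay, beyond the change at the methyl-bearing carbon shown by the earlier compounds. The core of compound 1 thus has a second place where a change shifts this read-out. No evidence is available that explains this step.

Going by these compounds, whether methoxy, a longer chain such as butoxy, or an amine at this carbon would shift the read-out differently remains open. So does the outcome of placing propoxy on the core of compound 2.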